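Lengthening the Ether Chain at the Assay Limit

The compounds below may be only part of what the source reports. "The series", "measured", "known", "first", "only" and "open" are said of these compounds alone.

Compound 1 `CN(Cc1cc(C(F)(F)F)cc(C(F)(F)F)c1)C(=O)c1c(OCCCC2CCN(C(=O)OC(C)(C)C)CC2)c2ccccc2n(C)c1=O` and compound 2 `COc1cc(CN(C)C(=O)c2c(OCCCC3CCN(C(=O)OC4(C)CC4)CC3)c3cccnc3n(C)c2=O)cc(OC)c1` carry a long, piperidine-bearing side chain on the shared core; in an ADME assay for inhibition of phosphatidylcholine:ceramide cholinephosphotransferase 1 (Homo sapiens), read by mass spectrometry, with stated times of 60 min and 30 min (a lower number here means a stronger inhibitor, a higher number a weaker inhibitor), compound 1 gives 3400 nM and compound 2 gives 18000 nM. Compound 3 `CCCOc1c(C(=O)N(C)Cc2cc(C(F)(F)F)cc(C(F)(F)F)c2)c(=O)n(C)c2ccccc12` has a short propoxy chain instead. In this assay compound 3 gives only a limit, > 100000 nM, so it sits at the limit of > 100000 nM in this assay, at which 1 of the 3 values shown sits, and no number is known for it. Compound 4 `CC(C)CCOc1c(C(=O)N(C)Cc2cc(C(F)(F)F)cc(C(F)(F)F)c2)c(=O)n(C)c2ccccc12` differs from compound 3 by isopropyl in place of methyl on a saturated chain carbon, two bonds along the chain from an oxygen on an aromatic ring. No measured step of this kind exists among the compounds shown, so the direction is open; in this assay the step is expected to be a number no higher from compound 3 to compound 4 (the limit leaves the size open), within the scatter. Compound 4 is therefore expected to give about 100000 nM, within 30000 nM to 300000 nM, in this assay, with a real chance that only a limit is reported again.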

Compound 4, half-maximal inhibitory concentration: > 100000 nM
Compound 4: no number, only a limit; the forecaster's own chance of this, stated with the estimate: 65%; the middle value lies on the limit itself.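

No step can be read from compound 3 to compound 4, since each gives only a limit: the limit of > 100000 nM in this assay, at which 2 of the 4 values shown sit. On these data alone, whether propoxy and isopentyloxy differ at all in this assay stays open, as does how weak either compound really is.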